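Phenoxy Added to a Tolerated Oxadiazolone

This account rests on a few compounds, and the source may have more. Where it says the series, first, only, none or still open, it means among the compounds named here.

Compound 1, `CCCCCCOc1nn(-c2ccccc2)c(=O)o1`: in a functional assay on RAW264.7 cells (Mus musculus) for cytotoxicity (a higher number here means that more compound is tolerated, a lower number that less compound is tolerated), compound 1 gives > 100000 nM, which is a limit of the assay rather than a number.
Compound 2, `CCCCCCCCCCCCCCCCOP1(=O)OCCC(C(=O)OC)=C(C)O1`: in this assay compound 2 gives > 100000 nM, likewise a limit.

Compound 1 therefore stands at the limit of > 100000 nM in this assay, at which 2 of the 2 values shown sit, and no measured number sets it apart from compound 2 in this assay. Within the data shown here, the two compounds share no common core, so no step between measured compounds can be drawn from them.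

Compound 3, `CCCCCCOc1nn(-c2ccc(Oc3ccccc3)cc2)c(=O)o1`, has not yet been measured in this assay. It differs from compound 1 in one place: phenoxy in place of hydrogen on an aromatic carbon. Among the measured compounds shown here, no pair of measured compounds shows what such a change does. The size of the step therefore has to be guessed from the fact that both measured compounds sit at the limit. In this assay the step is expected to be a number no higher from compound 1 to compound 3 (the limit leaves the size open), that is, none beyond the usual scatter, and a limit is the most likely read-out again. The estimate for compound 3 in this assay is 100000 nM, with a range from 30000 nM to 300000 nM.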

Compound 3, half-maximal cytotoxic concentration: > 100000 nM
Compound 3 gave a limit, no number; the forecaster's own chance of this, stated with the estimate: 65%; the middle value sits exactly at the limit.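

Among these compounds, no step from compound 1 to compound 3 can be read, since both give only a limit and not a number in this assay and the size of any difference stays hidden. The compounds shown leave open at what concentration any of them harms these cells, and whether phenoxy in place of hydrogen changes that concentration at all.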